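Changing the Benzyl Group on a Shared Core

This account rests on a few compounds, and the source may have more. Where it says the series, first, only, none or still open, it means among the compounds named here.

Measured so far in a functional assay on HL-60 cells (Homo sapiens) for antiproliferative activity, with a stated time of 72 h; a lower number here means a stronger inhibitor, a higher number a weaker inhibitor:
Compound 1 `OC[C@H]1O[C@@H](n2cnc3c(NCc4cccc(Br)c4)ncnc32)[C@H](O)[C@@H]1O` gives 8000 nM.
Compound 2 `Cc1cccc(CNc2ncnc3c2ncn3[C@@H]2O[C@H](CO)[C@@H](O)[C@H]2O)c1` gives 6400 nM.
Compound 3 `OC[C@H]1O[C@@H](n2cnc3c(NCc4ccc(Cl)c(Cl)c4)ncnc32)[C@H](O)[C@@H]1O` gives 2000 nM.

Compound 1 has the highest number of the three. Its nearest neighbour is compound 2, with a 1.3-fold lower number from compound 1 to compound 2 (0.10 log units; within the scatter), and its furthest is compound 3, with a 4.0-fold lower number from compound 1 to compound 3 (0.60 log units; beyond the scatter). Compound 4 `Cc1ccc(O)c(CNc2ncnc3c2ncn3[C@@H]2O[C@H](CO)[C@@H](O)[C@H]2O)c1` differs from compound 1 in one place: 2-hydroxy-5-methylphenyl in place of 3-bromophenyl on a saturated chain carbon bound to a nitrogen on an aromatic ring. The step from compound 1 to compound 2 also puts a methyl in place of a bromo, so it bears on this change, and it stayed within the scatter. For the measured compounds named here, no measured step speaks to the hydroxy part of the 2-hydroxy-5-methylphenyl group. The expected step is therefore small, no change at the digits printed from compound 1 to compound 4 (within the scatter). In this assay compound 4 is estimated at 8000 nM, with a range from 3000 nM to 20000 nM.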

Compound 4, half-maximal inhibitory concentration: 15000 nM
The estimate for compound 4 lay 1.9-fold (0.27 log units) below the measured number, within the range that was stated.
By their numbers in this assay, from the lowest: compound 3; then compounds 2, 1 and 4 (each within the scatter of the next, the first and the last beyond it).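

Putting a hydroxy in place of a hydrogen on the ring of compound 2 gives the first measured view of that group, and the number rises modestly (a 2.3-fold higher number from compound 2 to compound 4 (0.37 log units; beyond the scatter)). The full swap from the 3-bromophenyl group stays within the scatter (a 1.9-fold higher number from compound 1 to compound 4 (0.27 log units; within the scatter)), while the step from the 3,4-dichlorophenyl group is the largest seen so far (a 7.5-fold higher number from compound 3 to compound 4 (0.88 log units; beyond the scatter)). No available evidence explains these shifts. From the compounds shown here alone, whether a hydroxy would have the same effect on the 3,4-dichlorophenyl group remains open, as does the effect of an amine or a carboxylic acid in place of the hydroxy.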